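Hydroxy amide in place of the diester: compound 1 to compound 4

This account rests on a few compounds, and the source may have more. Where it says the series, first, only, none or still open, it means among the compounds named here.

Values in a functional assay on BXPC-3 cells (Homo sapiens) for antiproliferative activity, read by MTT assay, with a stated time of 24 h (on this read-out higher numbers stand for weaker inhibition and lower numbers for stronger inhibition), follow.
- compound 1 `CCn1c(C(=O)N[C@@H](CC(=O)OC)C(=O)OC)ccc1C(CC)(CC)c1ccc(OCS(=O)(=O)c2ccccc2)c(C)c1` gives > 50000 nM
- compound 2 `CCN(CC)CCNC(=O)c1ccc(C(CC)(CC)c2ccc(OCS(=O)(=O)c3ccccc3)c(C)c2)n1CC` gives 6270 nM
- compound 3 `CCn1c(C(=O)NCCO)ccc1C(CC)(CC)c1ccc(OCS(=O)(=O)c2ccccc2)c(C)c1` gives 19900 nM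

Compound 1 has no number, only a limit, and it stands at the limit of > 50000 nM in this assay, at which 1 of the 3 values shown sits. Any step out of compound 1 is therefore known only as a bound.

Compound 4 `CCn1c(C(=O)N[C@H](C)CO)ccc1C(CC)(CC)c1ccc(OCS(=O)(=O)c2ccccc2)c(C)c1` keeps the core of compound 1 and changes one group, (1-(hydroxymethyl)ethyl in place of 1,2-bis(methoxycarbonyl)ethyl on an amide-type nitrogen), with 1-(hydroxymethyl)ethyl in place of 1,2-bis(methoxycarbonyl)ethyl on an amide-type nitrogen.

Two measured steps replace the same group on that nitrogen. The closer one is an at least 2.5-fold lower number from compound 1 to compound 3 (0.40 log units; beyond the scatter), which brings in 2-hydroxyethyl, also a chain that carries a hydroxy group. The other is an at least 7.9-fold lower number from compound 1 to compound 2 (0.90 log units; beyond the scatter), which brings in 2-(diethylamino)ethyl. The basis for reading compound 4 with compound 3 rather than compound 2 is the hydroxy group shared with compound 3, and a 3.2-fold higher number from compound 2 to compound 3 (0.50 log units; beyond the scatter) shows that the two chains do not read alike.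

A step to a lower number is expected, of about the size of the closer step. The expected step is an at least 2.5-fold lower number from compound 1 to compound 4 (0.39 log units; beyond the scatter). For compound 4 the estimate is 20000 nM, with an expected range of 9000 nM to 45000 nM.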

Compound 4, half-maximal inhibitory concentration: 10000 nM
The estimate for compound 4 lay 2.0-fold (0.30 log units) above the measured number; measured number inside the range.
By their numbers in this assay, from the lowest: compounds 2, 4 and 3 (each within the scatter of the next, the first and the last beyond it). At a limit, above all of these: compound 1.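

In this assay, a third chain on the amide-type nitrogen now replaces 1,2-bis(methoxycarbonyl)ethyl, and the step, an at least 5.0-fold lower number from compound 1 to compound 4 (0.69 log units; beyond the scatter), can be read only as a bound, as compound 1 carries a limit and not a number: the limit of > 50000 nM in this assay, at which 1 of the 4 values shown sits.

The methyl on the saturated chain carbon bound to the amide-type nitrogen gives a 2.0-fold lower number from compound 3 to compound 4 (0.30 log units; within the scatter), so on this read-out the branched 1-(hydroxymethyl)ethyl chain cannot be told apart from the unbranched 2-hydroxyethyl chain. The comparison with the amine chain also changes: the earlier pair gave a 3.2-fold higher number from compound 2 to compound 3 (0.50 log units; beyond the scatter), yet the new pair gives a 1.6-fold higher number from compound 2 to compound 4 (0.20 log units; within the scatter), so a hydroxy-bearing chain is not separated from 2-(diethylamino)ethyl in every case, and compound 4 goes against any simple split between the two kinds of chain.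

Still open, going by these compounds, is whether a carboxylic acid or a longer hydroxy-bearing chain on this nitrogen would stay with compounds 2, 3 and 4 or fall back towards the limit held by compound 1. Also open is whether the mirror-image form of the 1-(hydroxymethyl)ethyl chain would read as compound 4 does, as only one form is shown.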